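Methoxy in place of methoxycarbonyl: cytotoxicity notes

The compounds below may be only part of what the source reports. "The series", "measured", "known", "first", "only" and "open" are said of these compounds alone.

In an ADME assay on HEK293 cells (Homo sapiens) for cytotoxicity, read by fluorescence and resazurin assay, with a stated time of 24 h (on this read-out higher numbers stand for lower toxicity in this test and lower numbers for higher toxicity in this test), compound 1 (`COc1ccccc1-c1nnc(SC2=CS(=O)(=O)c3ccccc32)o1`) gives 3000 nM and compound 2 (`COC(=O)c1ccc(-c2nnc(SC3=CS(=O)(=O)c4ccccc43)o2)cc1`) gives 4000 nM on a shared core, so compound 2 stands within the scatter of compound 1. Compound 3 (`COc1ccc(-c2nnc(SC3=CS(=O)(=O)c4ccccc43)o2)cc1`) has methoxy in place of methoxycarbonyl on an aromatic carbon, para to a large group (methoxy in place of methoxycarbonyl on an aromatic carbon). Within the data shown here, no measured step covers this change. Compound 1 also carries methoxy and gives 3000 nM so no step beyond the scatter is expected in this assay for this change. The estimated 1.1-fold lower number from compound 2 to compound 3 (0.06 log units; within the scatter) stays within the scatter. Compound 3 is expected at 3500 nM with an estimated range of 1500 nM to 8000 nM in this test.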

Compound 3, half-maximal cytotoxic concentration: 2000 nM
Beside the measured number, compound 3's estimate is 1.8-fold (0.24 log units) above it; low and high end bracket the measured number.
By their numbers in this assay, from the lowest: compounds 3, 1 and 2 (each within the scatter of the next).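

In this assay, methoxy in place of methoxycarbonyl on this aromatic carbon, para to a large group, gives a 2.0-fold lower number from compound 2 to compound 3 (0.30 log units; within the scatter), so the exchange of these two groups does not separate the compounds. Moving from 2-methoxyphenyl to 4-methoxyphenyl gives a 1.5-fold lower number from compound 1 to compound 3 (0.18 log units; within the scatter), so the two methoxy placements do not separate them either. No evidence on the origin of these small steps is at hand. As far as these compounds go, whether an amine or a carboxylic acid on this aromatic carbon would give a step beyond the scatter stays open.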